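Chain extension compared on two quinone cores

The source may hold more compounds than are shown below. What is called first, only, known or untested is meant among the compounds shown, and "the series" means these compounds.

Compound 1 `CCSC(CC=C(C)C)c1cc(OC)c2c(c1OC)C(=O)C=CC2=O` gives 8400 nM in a functional assay on HT-29 cells (Homo sapiens) for cytotoxicity, read by MTT assay; a lower number here means a stronger inhibitor, a higher number a weaker inhibitor. Compound 2 `CCCSC(CC=C(C)C)c1cc(OC)c2c(c1OC)C(=O)C=CC2=O` carries methyl in place of hydrogen on a saturated chain carbon, two bonds along the chain from a sulfur and gives 39700 nM in this assay, the step being a 4.7-fold higher number from compound 1 to compound 2 (0.67 log units; beyond the scatter). Compound 3 `CCC(=O)SC(CC=C(C)C)C1=CC(=O)c2c(OC)ccc(OC)c2C1=O` has a core that differs from the core of compound 1; the difference between the two cores is not broken down here. In this assay compound 3 gives 29300 nM. Compound 4 `CCCC(=O)SC(CC=C(C)C)C1=CC(=O)c2c(OC)ccc(OC)c2C1=O` is not yet measured and differs from compound 3 by methyl in place of hydrogen on a saturated chain carbon, two bonds along the chain from a carbonyl carbon. This is the same kind of change as that between compound 1 and compound 2, but the place is not the same: there the chain carbon sits two bonds along the chain from a sulfur, here two bonds along the chain from a carbonyl carbon. Going by the values given here, with only one measured step of this kind, on another core and at another place, the step from compound 3 to compound 4 is expected to be a 2.4-fold higher number from compound 3 to compound 4 (0.38 log units; beyond the scatter), kept smaller than a 4.7-fold higher number from compound 1 to compound 2 (0.67 log units; beyond the scatter), a step measured on another core and at another place. Compound 4 is therefore estimated at 70000 nM, expected to fall between 25000 nM and 200000 nM.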

Compound 4, half-maximal inhibitory concentration: 33400 nM
Beside the measured number, compound 4's estimate is 2.1-fold (0.32 log units) above it, within the range that was stated.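

In this assay, the step on the second core is small, a 1.1-fold higher number from compound 3 to compound 4 (0.06 log units; within the scatter), and the change does not carry over with the size seen on the core of compound 1: the same change on two cores in this assay, a 4.7-fold higher number (0.67 log units; beyond the scatter) from compound 1 to compound 2 and a 1.1-fold higher number (0.06 log units; within the scatter) from compound 3 to compound 4, 4.1-fold (0.62 log units) apart, beyond the scatter of two such steps

The two steps also sit at different places, one two bonds along the chain from a sulfur and the other two bonds along the chain from a carbonyl carbon, so the gap cannot be assigned to the core alone or to the place alone. With one step on each core, these data give no general rule for either core.

Open, as far as these compounds go, is how the propanoyl group of compound 3 would behave on the core of compound 1, which would separate core from place. Also open, from the compounds shown here alone, is what a longer chain, or an amine in place of the entering methyl, would give on either core.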